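The compounds below may be only part of what the source reports. "The series", "measured", "known", "first", "only" and "open" are said of these compounds alone.

Compound 1 `CNc1nc(NCCCN(C)C)c2sc(-c3ccc(C(F)(F)F)cc3)cc2n1`: 14 mL.min-1.g-1
Compound 2 `CNc1nc(NC(C)(C)C)c2sc(-c3ccc(C(F)(F)F)cc3)cc2n1`: 14 mL.min-1.g-1
Compound 3 `CNc1nc(NC2CC2)c2sc(-c3ccc(C(F)(F)F)cc3)cc2n1`: 25.2 mL.min-1.g-1

In an ADME assay (liver) for metabolic stability, with Liver microsome (Homo sapiens) as the target, read by LC-MS, using microsomes, tested at 0.1 uM (on this read-out higher numbers stand for fast clearance and lower numbers for slow clearance), compound 1 gives 14 mL.min-1.g-1, level with compound 2, and all three numbers lie within the scatter of each other. Compound 4 `CN(C)CCCNc1nc(N)nc2cc(-c3ccc(C(F)(F)F)cc3)sc12` differs from compound 1 by hydrogen in place of methyl on a nitrogen on an aromatic ring, in words methylamino to amino. Going by the values given here, no measured step changes the methylamino group, so the evidence is indirect. Changes on another nitrogen stayed within the scatter: no change at the digits printed from compound 1 to compound 2 (within the scatter), a 1.8-fold higher number from compound 1 to compound 3 (0.26 log units; within the scatter) and a 1.8-fold higher number from compound 2 to compound 3 (0.26 log units; within the scatter). On that basis, no step beyond the scatter is expected, and the expected step runs a 1.1-fold lower number from compound 1 to compound 4 (0.03 log units; within the scatter). For compound 4 the estimated value is 13 mL.min-1.g-1, with an expected range of 6.5 mL.min-1.g-1 to 26 mL.min-1.g-1.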

Compound 4, intrinsic clearance in microsomes: 16.9 mL.min-1.g-1
The estimate for compound 4 lay 1.3-fold (0.11 log units) below the measured number, within the range that was stated.
By their numbers in this assay, from the lowest: compounds 1, 2, 4 and 3 (each within the scatter of the next).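

In this assay, going by these compounds alone, the change from methylamino to amino gives a 1.2-fold higher number from compound 1 to compound 4 (0.08 log units; within the scatter) and is the first direct reading at this position. On the core of compound 1, this nitrogen on an aromatic ring therefore carries either hydrogen or methyl with no step beyond the scatter. Nothing measured here bears on the reason for this result.

Going by these compounds, whether ethylamino or a longer chain on this nitrogen stays within the scatter remains open. So does whether amino behaves the same alongside tert-butyl or cyclopropyl on the other nitrogen.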